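Methyl in place of phenyl on a shared core

This account rests on a few compounds, and the source may have more. Where it says the series, first, only, none or still open, it means among the compounds named here.

Compound 1, `CCCc1nc(C)c2c(CC)nnc(SC)n12`, in a functional assay for inhibition, with Homo sapiens as the target (a higher number here means a weaker inhibitor, a lower number a stronger inhibitor), gives > 48000 nM, which is a limit of the assay and not a number.
Compound 2, `CCCc1nc(C)c2c(-c3ccccc3)nnc(SC)n12`, in this assay gives > 48000 nM, again a limit of the assay.
Compound 3, `CSc1nnc(-c2ccccc2)c2c(C)nc(C(C)C)n12`, in this assay gives > 48000 nM, also a limit of the assay.

Compound 2 therefore stands at the limit, as do the other two measured compounds: the limit of > 48000 nM in this assay, at which 3 of the 3 values shown sit. The change considered here leads to compound 4, `CCCc1nc(C)c2c(C)nnc(SC)n12`, and is methyl in place of phenyl on an aromatic carbon. For the measured compounds named here, two measured steps bear on this kind of change. The step that the two limits leave unreadable from compound 1 to compound 2 cannot be read, and the step that the two limits leave unreadable from compound 2 to compound 3 cannot be read either, since both ends of each sit at the limit. No readable step is available, and the change at this position, from phenyl back to a small group, resembles the reversal of the step from compound 1 to compound 2, which gave no number. For compound 4 a value at the limit is therefore expected, with a step that the limit leaves unreadable from compound 2 to compound 4 most likely not readable. Compound 4 is estimated at 100000 nM in this assay, within 30000 nM to 500000 nM.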

Compound 4, half-maximal inhibitory concentration: > 48000 nM
Compound 4 gave a limit, no number (the forecaster's own chance of this, stated with the estimate: 85%); the middle value is on the limit's open side.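

In this assay compound 4 gives > 48000 nM, a limit of the assay and not a number. The steps to compound 4 from compound 1 and compound 2 therefore cannot be read: the limit of > 48000 nM in this assay, at which 4 of the 4 values shown sit. The compounds shown leave open how strongly, if at all, any of them inhibits.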